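A Small Halogen Swap on a Shared Core

The source may hold more compounds than are shown below. What is called first, only, known or untested is meant among the compounds shown, and "the series" means these compounds.

Two measured compounds share one core and differ in one place. Compound 1 `CNC(=O)c1cc(Oc2ccc3nc(NC(=O)Nc4cc(C(F)(F)F)cc(C(F)(F)F)c4)sc3c2)ccn1` gives 88.1% in a functional assay on SK-BR-3 cells (Homo sapiens) for inhibition, read by MTT assay, with a stated time of 2 days, tested at 10 uM; on this read-out higher numbers stand for more inhibition of growth at the one concentration tested and lower numbers for less inhibition of growth. Compound 2 `CNC(=O)c1cc(Oc2ccc3nc(NC(=O)Nc4ccc(Cl)cc4)sc3c2)ccn1` gives 50.8% in this assay, the lower of the two numbers, and its gap to compound 1 lies beyond the usual scatter. Compound 3 `CNC(=O)c1cc(Oc2ccc3nc(NC(=O)Nc4ccc(F)cc4)sc3c2)ccn1` is compound 2 with fluoro in place of chloro on an aromatic carbon. Within the data shown here, no measured step of this kind exists here, so only a small change in this assay is expected, if anything slightly downward, likely within the scatter. Compound 3 is expected to give 45%, within 25% to 65%, meaning a step of a number 5.8 percentage points lower from compound 2 to compound 3 (within the scatter).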

Compound 3, percent growth inhibition at one concentration: 14.2%
The estimate for compound 3 lay 30.8 percentage points above the measured number; measured number outside the range, below it.
By their numbers in this assay, from the lowest: compound 3; then compound 2; then compound 1.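

In this assay, the change from 4-chlorophenyl to 4-fluorophenyl gives a number 36.6 percentage points lower from compound 2 to compound 3 (beyond the scatter) and so shows that this position is sensitive to which halogen it carries. Even a swap of one heavy atom for one heavy atom, with no change in ring, charge or hydrogen-bond counts, can matter greatly here. The data offer no explanation for this sensitivity.

Open, as far as these compounds go, is whether a bromo or a methoxy group at this same place would read closer to compound 2 or to compound 3. Also open, from the compounds shown here alone, is how a hydrogen there, with no halogen at all, would compare.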